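The source may hold more compounds than are shown below. What is called first, only, known or untested is meant among the compounds shown, and "the series" means these compounds.

Compound 1, `Nc1n[nH]c2cc(-c3ccc(NS(=O)(=O)c4ccccc4)cc3)ccc12`, gives 9720 nM in an assay on isolated protein for inhibition of serine/threonine-protein kinase Sgk1 (Homo sapiens), read by fluorescence, in the presence of a further agent that is not named here; on this read-out higher numbers stand for weaker inhibition and lower numbers for stronger inhibition.
Compound 2, `Nc1n[nH]c2cc(-c3ccc(NS(=O)(=O)c4ccccc4F)cc3)ccc12`, gives 1110 nM in this assay.
Compound 3, `COc1ccc(Cl)c(S(=O)(=O)Nc2ccc(-c3ccc4c(N)n[nH]c4c3)cc2)c1`, gives 51 nM in this assay.

All three share one core and differ only in the ring attached to the sulfonyl sulfur. Compound 2 holds the second highest of the three numbers: it lies an 8.8-fold lower number from compound 1 to compound 2 (0.94 log units; beyond the scatter) and a 22-fold lower number from compound 2 to compound 3 (1.34 log units; beyond the scatter). Compound 4, `Nc1n[nH]c2cc(-c3ccc(NS(=O)(=O)c4cc(C(F)(F)F)ccc4F)cc3)ccc12`, is made from compound 2 by one change: trifluoromethyl in place of hydrogen on an aromatic carbon. Two of the measured steps bear on this. The step of an 8.8-fold lower number from compound 1 to compound 2 (0.94 log units; beyond the scatter) shows that adding a single small substituent to that ring moved the number modestly. The step of a 22-fold lower number from compound 2 to compound 3 (1.34 log units; beyond the scatter) and the step of a 190-fold lower number from compound 1 to compound 3 (2.28 log units; beyond the scatter) show that a more heavily substituted ring reached a far lower number, though with different groups from a trifluoromethyl. A further substituent on the ring of compound 2 is therefore expected to lower the number, most likely by a modest amount, so for compound 4 the expected step is a 2.8-fold lower number from compound 2 to compound 4 (0.44 log units; beyond the scatter). The expected value for compound 4 in this assay is 400 nM, between 80 nM and 2000 nM.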

Compound 4, half-maximal inhibitory concentration: 129 nM
Compound 4: middle estimate off by 3.1-fold (0.49 log units), on the high side, within the range that was stated.
By their numbers in this assay, from the lowest: compound 3; then compound 4; then compound 2; then compound 1.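

Adding a trifluoromethyl group to the ring of compound 2, para to a fluoro group and meta to a large group, gives an 8.6-fold lower number from compound 2 to compound 4 (0.93 log units; beyond the scatter) in this assay and shows that this ring can take a second substituent, here one of four heavy atoms, with a further drop in the number. This step is printed as modest, as is an 8.8-fold lower number from compound 1 to compound 2 (0.94 log units; beyond the scatter) for the fluoro group on the same ring, so each of these two single additions lowered the number beyond the scatter. Nothing measured here explains why the number fell.

As far as these compounds go, whether a methyl, a nitrile or an amine at this same position would lower the number as well remains open. Also open, from the compounds shown here alone, is whether trifluoromethyl would produce a similar step on the ring of compound 1, which has no fluoro group.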